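A Bromo Substituent on the Ring of Compound 2

This account rests on a few compounds, and the source may have more. Where it says the series, first, only, none or still open, it means among the compounds named here.

Compound 1 `COc1ccc(C(F)(F)F)cc1NC(=O)CN1CCN(S(=O)(=O)N2CCC(C)CC2)CC1` gives 2400 nM in an assay on HEK293 cells for inhibition of potassium channel subfamily T member 1 (Homo sapiens), read by thallium flux; on this read-out lower numbers stand for stronger inhibition and higher numbers for weaker inhibition. Compound 2 `COc1ccccc1NC(=O)CN1CCN(S(=O)(=O)N2CCC(C)CC2)CC1` reports only a limit, not a number: > 10000 nM. Compound 3 `COc1ccc(Cl)cc1NC(=O)CN(C)CCN(C)S(=O)(=O)N1CCC(C)CC1` likewise reports only a limit: > 10000 nM.

Compound 2 therefore stands at the limit of this assay, and two of the three values shown sit there (the limit of > 10000 nM in this assay, at which 2 of the 3 values shown sit). Compound 4 `COc1ccc(Br)cc1NC(=O)CN1CCN(S(=O)(=O)N2CCC(C)CC2)CC1` differs from compound 2 by bromo in place of hydrogen on an aromatic carbon. For the measured compounds named here, the one measured step touching that carbon is an at least 4.1-fold higher number from compound 1 to compound 2 (0.61 log units; beyond the scatter), where a large group left and the number rose beyond the scatter. Adding bromo runs the other way, so a drop back to a measurable number is expected, with a step of an at least 2.5-fold lower number from compound 2 to compound 4 (0.39 log units; beyond the scatter). Compound 4 is estimated at 4000 nM, between 1500 nM and 15000 nM.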

Compound 4, half-maximal inhibitory concentration: 1400 nM
Compound 4: the middle estimate sits 2.9-fold (0.46 log units) above what was measured; measured number below the stated range.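

In this assay, a single bromine atom on the carbon para to a methoxy group is enough to return a measurable number, with an at least 7.1-fold lower number from compound 2 to compound 4 (0.85 log units; beyond the scatter) for that one change. For the compounds shown here, with a 1.7-fold lower number from compound 1 to compound 4 (0.23 log units; within the scatter) between them, bromo and trifluoromethyl on this carbon cannot be told apart, so trifluoromethyl is not the only group there that gives a measurable number. The first step is a bound rather than a size, because compound 2 reports only a limit: the limit of > 10000 nM in this assay, at which 2 of the 4 values shown sit.

As far as these compounds go, whether fluoro, a nitrile or an amine on this carbon would also give a measurable number stays open. So does whether a larger group, such as phenyl, would take the number lower still.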